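The compounds below may be only part of what the source reports. "The series", "measured", "known", "first", "only" and "open" are said of these compounds alone.

In an assay on CHO cells for displacement of a labelled ligand from Substance-P receptor (Homo sapiens), with a stated time of 90 min (a higher number here means a weaker inhibitor, a lower number a stronger inhibitor), compound 2 `Cc1nc(N2CCN(C)CC2)cc(-c2ccccc2)c1C(=O)N(C)Cc1cc(C(F)(F)F)cc(C(F)(F)F)c1` gives 4.8 nM, the lowest of the two numbers measured, and compound 1 `Cc1nc(Cl)cc(-c2ccccc2)c1C(=O)N(C)Cc1cc(C(F)(F)F)cc(C(F)(F)F)c1` gives 91 nM. Compound 3 `Cc1cc(-c2ccccc2)c(C(=O)N(C)Cc2cc(C(F)(F)F)cc(C(F)(F)F)c2)c(C)n1` differs from compound 2 by methyl in place of 4-methylpiperazin-1-yl on an aromatic carbon. For the measured compounds named here, one measured step bears on this change, in the opposite direction: a 19-fold lower number from compound 1 to compound 2 (1.28 log units; beyond the scatter). Because that step a 19-fold lower number from compound 1 to compound 2 (1.28 log units; beyond the scatter) came with the 4-methylpiperazin-1-yl group entering, its departure here is expected to undo most of it, so a step of a 13-fold higher number from compound 2 to compound 3 (1.10 log units; beyond the scatter) is expected. Compound 3 is therefore estimated at 60 nM, with a range from 20 nM to 200 nM.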

Compound 3, half-maximal inhibitory concentration: 41 nM
Compound 3: middle estimate off by 1.5-fold (0.17 log units), on the high side; the range from low to high includes it.
By their numbers in this assay, from the lowest: compound 2; then compound 3; then compound 1.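

In this assay, replacing the 4-methylpiperazin-1-yl group with a single methyl loses most of the gain, but not all of it (in numbers, an 8.5-fold higher number from compound 2 to compound 3 (0.93 log units; beyond the scatter)). Methyl and chloro also differ at this position (here, a 2.2-fold lower number from compound 1 to compound 3 (0.35 log units; beyond the scatter)), so the outcome does not simply depend on whether the piperazine is present. The three groups rank 4-methylpiperazin-1-yl, then methyl, then chloro, from lowest number to highest. The compounds shown leave open whether a smaller amine such as dimethylamino, or a morpholine ring, would match compound 2. Nothing measured here explains this order.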